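Capping the ring amine: expected cytotoxicity of compound 4

A few compounds are considered here, and "the series" means these few. Any claim that something is new, unique, unknown or untested is made for them only; others in the source may bear on it.

Measured so far in a toxicity assay on MT4 cells (Homo sapiens) for cytotoxicity, read by MTT assay, with a stated time of 7 days; on this read-out higher numbers stand for lower toxicity in this test and lower numbers for higher toxicity in this test:
Compound 1 `Cc1cc(C)cc(S(=O)(=O)c2c(C(=O)NC3CC4(CCN(Cc5n[nH]c(=O)n5C)C4)C3)[nH]c3ccc(Cl)cc23)c1` gives > 214000 nM, which is a limit of this test and not a number.
Compound 2 `Cc1cc(C)cc(S(=O)(=O)c2c(C(=O)NC3CC4(CCN(Cc5n[nH]c(=O)n5C)CC4)C3)[nH]c3ccc(Cl)cc23)c1` gives 178000 nM.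
Compound 3 `Cc1cc(C)cc(S(=O)(=O)c2c(C(=O)NC3CC4(CCNC4)C3)[nH]c3ccc(Cl)cc23)c1` gives 25300 nM.

Of the numbers shown, compound 3 has the lowest, with compound 2 the nearest; compound 1 sits at a limit. Going by the values given here, only one step joins measured compounds that differ in a single place: an at least 8.4-fold lower number from compound 1 to compound 3 (0.92 log units; beyond the scatter). Removing the substituent from the amine nitrogen in the ring thus lowered the number.

Compound 4 `Cc1cc(C)cc(S(=O)(=O)c2c(C(=O)NC3CC4(C3)CN(S(C)(=O)=O)C4)[nH]c3ccc(Cl)cc23)c1` has not yet been measured. It differs from compound 3 by a group of 11 heavy atoms (7 carbon, 1 nitrogen, 2 oxygen, 1 sulfur; one four-membered non-aromatic ring of carbon only, one four-membered non-aromatic ring with 1 hetero atom) in place of a group of 8 heavy atoms (7 carbon, 1 nitrogen; one four-membered non-aromatic ring of carbon only, one five-membered non-aromatic ring with 1 hetero atom), on an amide-type nitrogen. Among the compounds with values here, the ring nitrogen that is free in compound 3 is again capped in compound 4, now by a methanesulfonyl, so the change runs in the sense opposite to an at least 8.4-fold lower number from compound 1 to compound 3 (0.92 log units; beyond the scatter), and that step is the only guide available. A rise in the number, beyond the scatter, is therefore expected: a 5.9-fold higher number from compound 3 to compound 4 (0.77 log units; beyond the scatter). Compound 4 is estimated at 150000 nM, within a range from 50000 nM to 300000 nM. The upper end of that range reaches the region of the limit of > 214000 nM in this assay, at which 1 of the 3 values shown sits, so a limit rather than a number is a real possibility for compound 4.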

Compound 4, half-maximal cytotoxic concentration: > 233000 nM
Compound 4 was reported as a limit; the forecaster's own chance of this, stated with the estimate: 30%; middle value at least 1.5-fold (0.19 log units) away from the limit.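

In this assay, going by these compounds alone, the entering group on the amide-type nitrogen, which carries a methanesulfonyl and a four-membered non-aromatic ring with 1 hetero atom, gives a clear gain over compound 3 (an at least 9.2-fold higher number from compound 3 to compound 4 (0.96 log units; beyond the scatter)), so a group other than the one in compound 1 is also tied to a higher number than the uncapped compound 3 shows. Compound 4 stands at a limit of this test and not at a number, so the step gives only a lower bound on the size of the change: the limit of > 233000 nM in this assay, at which 1 of the 4 values shown sits. Unlike the earlier step, in which only the group on the amine nitrogen changed, this one also replaces a five-membered non-aromatic ring with 1 hetero atom by a four-membered one, and it ends with 0 hydrogen-bond donors in the entering group, where the leaving group had 1.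

The compounds shown leave open how much of the step belongs to the methanesulfonyl and how much to the smaller ring, since the two change together here. They also leave open whether a smaller cap, such as an acetyl or a single methyl, would bring a comparable rise in this read-out.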